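The compounds below may be only part of what the source reports. "The series", "measured", "known", "first", "only" and "open" are said of these compounds alone.

Compound 3 (`C=CC1=C(C(=O)NC(C)(C)C)C(c2ccc(OC)cc2)OC1`) carries a tert-butyl group on its amide nitrogen. In a functional assay on SW480 cells (Homo sapiens) for cytotoxicity, read by MTT assay, with a stated time of 24 h (a lower number here means a stronger inhibitor, a higher number a weaker inhibitor), compound 3 gives > 100000 nM, which is a limit of the assay and not a number. Compound 2 (`C=CC1=C(C(=O)O)C(c2ccc(OC)cc2)OC1`) likewise gives > 100000 nM, again only a limit. Compound 1 (`C=CC1=C(C(=O)NCc2ccccc2)C(c2ccc(OC)cc2)OC1`), with benzyl on that nitrogen, gives 39500 nM. Swapping benzyl for tert-butyl was an at least 2.5-fold higher number from compound 1 to compound 3 (0.40 log units; beyond the scatter), swapping benzylamino for hydroxy was an at least 2.5-fold higher number from compound 1 to compound 2 (0.40 log units; beyond the scatter), and the step between the two limits is a step that the two limits leave unreadable from compound 2 to compound 3 because of the limit of > 100000 nM in this assay, at which 2 of the 3 values shown sit. Compound 4 (`C=CC1=C(C(=O)Nc2ccc(OCC)cc2)C(c2ccc(OC)cc2)OC1`) differs from compound 3 by 4-ethoxyphenyl in place of tert-butyl on an amide-type nitrogen. The step of an at least 2.5-fold higher number from compound 1 to compound 3 (0.40 log units; beyond the scatter) came with leaving an aromatic ring, so returning to an aromatic ring in compound 4 is expected to undo it. Compound 4 is therefore estimated at 40000 nM (range 12000 nM to 120000 nM), an expected step of an at least 2.5-fold lower number from compound 3 to compound 4 (0.39 log units; beyond the scatter).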

Compound 4, half-maximal inhibitory concentration: > 100000 nM
Compound 4 gave a limit, no number; the forecaster's own chance of this, stated with the estimate: 35%; middle value at least 2.5-fold (0.39 log units) from the limit.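

An aromatic ring on the amide nitrogen is therefore not enough on its own: 4-ethoxyphenyl in place of benzyl gives an at least 2.5-fold higher number from compound 1 to compound 4 (0.40 log units; beyond the scatter). Compound 4 gives only a limit of the assay, not a number. The step from compound 3 to compound 4, like the one from compound 2, cannot be read because both ends are limits: the limit of > 100000 nM in this assay, at which 3 of the 4 values shown sit.

The compounds shown leave open whether the ethoxy group or the loss of the benzyl carbon separates compound 4 from compound 1. An unsubstituted phenyl or a 2-phenylethyl group on the amide nitrogen would speak to that.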